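The compounds below may be only part of what the source reports. "The series", "measured", "known", "first", "only" and "open" are said of these compounds alone.

Compound 1 `Nc1ccc2[nH]c(-c3ccc(Cl)c(Cl)c3)cc2c1` is one of three compounds with a measurement in an assay on isolated protein for inhibition of Aromatase (Homo sapiens), read by fluorescence, using NADPH, with a stated time of 30 min, tested at 50 uM; on this read-out lower numbers stand for less inhibition and higher numbers for more inhibition at the one concentration tested (going by the name of the read-out). In this assay compound 1 gives 21.4%. Compound 2 `Cn1c(-c2ccc(Cl)c(Cl)c2)cc2cc(N)ccc21` differs from compound 1 by a methyl in place of hydrogen on an aromatic nitrogen, and compound 2 gives 42%. Among the compounds with values here, that change is the only measured step between neighbours here, and it runs as a number 20.6 percentage points higher from compound 1 to compound 2 (beyond the scatter). Compound 3 `Brc1ccc(-c2cc3ccccc3[nH]2)cc1` gives 4.8%. Compound 1 therefore stands second of the three numbers, beyond the scatter from compound 3 below it and from compound 2 above it.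

Compound 4 `Clc1ccc(-c2cc3ccccc3[nH]2)cc1Cl` differs from compound 1 by hydrogen in place of amino on an aromatic carbon. Within the data shown here, no measured step removes the amino group, so the step from compound 1 to compound 2 does not bear on this change directly. Among the measured compounds shown here, compound 3 is the only measured compound without the amino group, and compound 3 at 4.8% lies well under compound 1, though its halogen pattern also differs. A drop is therefore expected. The step expected is a number 13.4 percentage points lower from compound 1 to compound 4 (beyond the scatter). Compound 4 is estimated to give about 8%, within a range from 0% to 20%.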

Compound 4, a percentage reported as inhibition, at one concentration (the size of the read-out at that concentration, not a potency): 22.7%
Compound 4: middle estimate off by 14.7 percentage points, on the low side; measured number outside the range, above it.
By their numbers in this assay, from the lowest: compound 3; then compounds 1 and 4 (each within the scatter of the next); then compound 2.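

Removing the amino group from this aromatic carbon gives a number 1.3 percentage points higher from compound 1 to compound 4 (within the scatter) in this assay, so on this read-out, at the one concentration tested, the amino compound and its hydrogen counterpart cannot be told apart. The earlier compounds shown here offered no pair that isolated this group, and this pair shows that the amino group is not needed for compound 4 to reach a number of this size. Nothing at hand bears on why the swap leaves the number within the scatter.

Still open, going by these compounds, is whether other groups on this carbon, such as a hydroxyl, a methoxy or a carboxylic acid, would also leave the number within the scatter. Also open, on these data alone, is whether a methyl on the aromatic nitrogen of compound 4 would give a step like the one seen with the amino group present.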